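Cytotoxicity notes on compounds 1 to 4

A few compounds are considered here, and "the series" means these few. Any claim that something is new, unique, unknown or untested is made for them only; others in the source may bear on it.

Three compounds have been run in an ADME assay on PC-3 cells (Homo sapiens) for cytotoxicity, read by WST assay, tested at 100 uM; a higher number here means more inhibition at the concentration tested (going by the name of the read-out), a lower number less inhibition. Compound 1 `CS(=O)(=O)Nc1cccc(C(=O)N2CCCC(C(=O)Nc3ccc(Cl)cc3)C2)c1` gives 3%, and compound 3 `CSc1cccc(C(=O)N2CCCC(C(=O)Nc3ccc(Cl)cc3)C2)c1` gives 0%. Within the data shown here, the one measured step that changes a single place, a number 3 percentage points lower from compound 1 to compound 3 (within the scatter), leaves the number essentially where it was. Compound 2 `CCc1cccc(NC(=O)C2CCCN(C(=O)c3cc(C(F)(F)F)cc(C(F)(F)F)c3)C2)c1` gives 0% in this assay, level with compound 3 at the digits shown and together with it the lowest of the three numbers, while compound 1 is the furthest at a gap that still lies inside the scatter. Compound 4 `O=C(Nc1cccc(-c2cnco2)c1)C1CCCN(C(=O)c2cc(C(F)(F)F)cc(C(F)(F)F)c2)C1` differs from compound 2 in one place: 1,3-oxazol-5-yl in place of ethyl on an aromatic carbon. No measured step alters this position; the single step shown touches another part of the shared core and was within the scatter, and all three numbers sit at the bottom of the scale. The expectation for compound 4 is therefore no step beyond the scatter, a number 3 percentage points higher from compound 2 to compound 4 (within the scatter). Compound 4 is estimated at 3%, from -8% to 18%.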

Compound 4, a percentage reported as inhibition, at one concentration (the size of the read-out at that concentration, not a potency): 9%
Beside the measured number, compound 4's estimate is 6 percentage points below it; low and high end bracket the measured number.
By their numbers in this assay, from the lowest: compounds 2, 3, 1 and 4 (each within the scatter of the next).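

Among these compounds, this position now has a measured step in this assay, a number 9 percentage points higher from compound 2 to compound 4 (within the scatter), whereas the only earlier step lay elsewhere on the shared core. Replacing ethyl, which has no ring and no hydrogen-bond acceptors, with 1,3-oxazol-5-yl, a five-membered aromatic ring with 2 hydrogen-bond acceptors, therefore leaves the reading within the scatter, even though this is a larger change in atoms and ring count. No measurement shown here accounts for the size of this step.

No step shown so far lies beyond the scatter, so it remains open whether any change at this position can move the number that far. An amine, a carboxylic acid or a longer alkyl chain on the same aromatic carbon would test that directly.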